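Para substituent swap on the arylpiperazine: methoxy to nitro

The compounds below may be only part of what the source reports. "The series", "measured", "known", "first", "only" and "open" are said of these compounds alone.

Among the compounds with values here, compound 3 `COc1ccc(N2CCN(CC(=O)N3CCN(c4nnc(-c5ccc(C)cc5)c(-c5ccc(C)cc5)n4)CC3)CC2)cc1` is the one member of the series with a number in an ADME assay on NIH3T3 cells (Mus musculus) for cytotoxicity, read by MTT assay, with a stated time of 24 h; on this read-out lower numbers stand for stronger inhibition and higher numbers for weaker inhibition: compound 3 gives 116000 nM. Compound 1 `Cc1ccc(-c2nnc(N3CCN(C(=O)CN4CCN(c5ccccc5Cl)CC4)CC3)nc2-c2ccc(C)cc2)cc1` reaches only > 859000 nM, which is a limit of the assay. Compound 2 `COc1cccc(N2CCN(CC(=O)N3CCN(c4nnc(-c5ccc(C)cc5)c(-c5ccc(C)cc5)n4)CC3)CC2)c1` likewise reaches > 866000 nM, a limit of the assay. Within the data shown here, compound 3 therefore holds the only readable number, with the two other values standing at limits.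

Compound 4 `Cc1ccc(-c2nnc(N3CCN(C(=O)CN4CCN(c5ccc([N+](=O)[O-])cc5)CC4)CC3)nc2-c2ccc(C)cc2)cc1` differs from compound 3 by nitro in place of methoxy on an aromatic carbon, that is 4-methoxyphenyl to 4-nitrophenyl.

Among the measured compounds shown here, two measured steps touch the same ring on the amine nitrogen. The step of an at least 7.4-fold lower number from compound 1 to compound 3 (0.86 log units; beyond the scatter) and the step of an at least 7.4-fold lower number from compound 2 to compound 3 (0.87 log units; beyond the scatter) both end at compound 3, each read against the limit of > 859000 nM in this assay, at which 1 of the 3 values shown sits, and (the limit of > 866000 nM in this assay, at which 1 of the 3 values shown sits). The step that the two limits leave unreadable from compound 1 to compound 2 cannot be read. Both known changes away from 4-methoxyphenyl thus correspond to higher numbers, and no change at this ring has so far given a number near that of compound 3. For compound 4 the expectation is therefore a higher number, a 3.4-fold higher number from compound 3 to compound 4 (0.54 log units; beyond the scatter), with a real chance that only a limit is returned. Compound 4 is expected at 400000 nM, in a range from 130000 nM to 1000000 nM.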

Compound 4, half-maximal inhibitory concentration: > 844000 nM
Compound 4: only a limit was reported; the forecaster's own chance of this, stated with the estimate: 45%; at least 2.1-fold (0.32 log units) between middle value and limit.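

Nitro in place of methoxy on an aromatic carbon, para to a large group, brings an at least 7.2-fold higher number from compound 3 to compound 4 (0.86 log units; beyond the scatter) in this assay. Within the data shown here, the value of compound 4 is a limit of the assay and not a number: the limit of > 844000 nM in this assay, at which 1 of the 4 values shown sits. The earlier compounds changed where the group sat or what it was, with 3-methoxyphenyl in compound 2 and 2-chlorophenyl in compound 1, whereas compound 4 keeps a group in the same place as compound 3 and still gives no readable number, so occupying this place is not enough on its own and the readable number in this set belongs to 4-methoxyphenyl alone.

The steps from compound 1 to compound 4 and from compound 2 to compound 4 cannot be read, both ends being limits, so any order among these three compounds stays open, as does how far each lies from compound 3. As far as these compounds go, whether a readable number returns with another group in the same place, such as ethoxy, hydroxy or a dimethylamino group, remains open, and a single methoxy-to-nitro pair gives no general rule for this ring.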